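Urea aryl change on the shared core: compound 3 to compound 4

The source may hold more compounds than are shown below. What is called first, only, known or untested is meant among the compounds shown, and "the series" means these compounds.

Of the compounds shown here, three have been tested in a functional assay on MDA-MB-231 cells (Homo sapiens) for antiproliferative activity, read by MTT assay, with a stated time of 72 h; on this read-out lower numbers stand for stronger inhibition and higher numbers for weaker inhibition. Compound 1 `NS(=O)(=O)c1ccc(S(=O)(=O)Nc2cccc(-c3nc(-c4ccc(NC(=O)c5cccnc5)cc4Cl)no3)c2)cc1` gives only a limit, > 10000 nM. Compound 2 `COc1cc(NC(=O)c2cccnc2)ccc1-c1noc(-c2cccc(NS(=O)(=O)c3ccc(NC(C)=O)cc3)c2)n1` likewise gives only a limit, > 10000 nM. Compound 3 `O=C(Nc1ccc(Cl)cc1)Nc1cccc(-c2nc(-c3ccc(NC(=O)c4cccnc4)cc3Cl)no2)c1` also gives only a limit in this assay, > 10000 nM. Compound 3 therefore stands at the same position as the other two, which is the limit of > 10000 nM in this assay, at which 3 of the 3 values shown sit; no number separates any of the three, and no order among them can be read.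

Compound 4 `CS(=O)(=O)Nc1ccc(NC(=O)Nc2cccc(-c3nc(-c4ccc(NC(=O)c5cccnc5)cc4Cl)no3)c2)cc1Cl` differs from compound 3 in one place: 3-chloro-4-(methanesulfonamido)phenyl in place of 4-chlorophenyl on an amide-type nitrogen. The group that enters brings a hydrogen-bond donor and two acceptors on the ring attached to the urea nitrogen, while the rest of the shared core is unchanged.

Among the compounds with values here, because every measured value sits at the limit of > 10000 nM in this assay, at which 3 of the 3 values shown sit, there is no measured step from which the effect of a change at this position could be gauged. The expected step from compound 3 to compound 4 is a step that the limit leaves unreadable from compound 3 to compound 4, that is, no movement beyond the scatter, with a limit again the most likely outcome. The estimate for compound 4 in this assay is 15000 nM, within 4000 nM to 60000 nM.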

Compound 4, half-maximal inhibitory concentration: 600 nM
Compound 4: middle estimate off by 25-fold (1.40 log units), on the high side, outside the stated range (below it).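

In this assay the aryl group on the urea nitrogen proves able to move the read-out, with an at least 16-fold lower number from compound 3 to compound 4 (1.22 log units; beyond the scatter) while the rest of the shared core stays unchanged. The earlier compounds shown here gave no sign of this: the core with a urea is not inactive as such, and with 3-chloro-4-(methanesulfonamido)phenyl in place of 4-chlorophenyl it reaches a measured number, so this position now has a readable response. Compound 4 is the only compound shown with a number rather than a limit, so this single step is all that can be read so far: the limit of > 10000 nM in this assay, at which 3 of the 4 values shown sit.

The change moves the chlorine and adds the methanesulfonamido group in one step, and the compounds shown do not separate the two, so the step cannot be assigned to either part of the new ring. Also open, as far as these compounds go, is whether the gain survives with an amine, a carboxylic acid or a longer alkanesulfonamide chain in place of the methanesulfonamido group, and whether the same aryl group gives a number on the cores of compound 1 or compound 2.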